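Cinnamyl for dichlorobenzyl on a nucleoside scaffold

The source may report more compounds than this note shows. Statements on the series, on what has been measured and on what is new or still open speak of the compounds shown alone.

Of the compounds shown here, three have been measured in a functional assay on the whole organism (B cells) with Mus musculus as the target; a higher number here means a larger maximal response, a lower number a smaller maximal response. Compound 1 `C=CCN1C(=C(C(=O)OCC)C(=O)OCC)N([C@H]2OC(CO)[C@H]3OC(C)(C)O[C@H]32)c2cc(N)nc(O)c21` gives 0% in this assay, compound 2 `CCCn1c(=O)n(C2CCC(CO)O2)c2nc(NC(=O)C(C)(C)C)nc(O)c21` gives 19%, and compound 3 `Nc1nc(O)c2c(n1)n(C1OC(CO)[C@@H](O)[C@H]1O)c(=O)n2Cc1ccc(Cl)c(Cl)c1` gives 55%, the highest of the three, standing beyond the scatter above both compound 2 and compound 1. Compound 4 `Nc1nc(O)c2c(n1)n(C1OC(CO)[C@@H](O)[C@H]1O)c(=O)n2C/C=C/c1ccccc1` is the unmeasured partner of compound 3, and the difference between them is 2-phenylethenyl in place of 3,4-dichlorophenyl on a saturated chain carbon bound to an aromatic nitrogen. Going by the values given here, no measured pair shows this kind of change, so any expectation rests on compound 3 alone. The expected step is a number 10 percentage points lower from compound 3 to compound 4 (within the scatter), a modest fall that may not exceed the usual scatter. Compound 4 is therefore estimated to reach 45% in this assay, with a range from 20% to 75%.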

Compound 4, largest response reached (reported as maximal response), in percent of the reference or control that the assay uses: 73%
Beside the measured number, compound 4's estimate is 28 percentage points below it; measured number inside the range.
By their numbers in this assay, from the lowest: compound 1; then compound 2; then compound 3; then compound 4.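

In this assay, the place on a saturated chain carbon bound to an aromatic nitrogen tolerates more than compound 3 alone could show: 2-phenylethenyl in place of 3,4-dichlorophenyl gives a number 18 percentage points higher from compound 3 to compound 4 (beyond the scatter) and compound 4 now ranks highest of the series. The chlorine atoms are thus not needed for a large maximal response. Nothing shown explains this rise.

Going by these compounds, it stays open whether the double bond or the loss of chlorine carries the step: an unsubstituted benzyl or a saturated 3-phenylpropyl group at this place would separate the two. How an amine or a carboxylic acid there would fare is also unknown.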